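Adding Ethyl to the Chain of Compound 3

The compounds below may be only part of what the source reports. "The series", "measured", "known", "first", "only" and "open" are said of these compounds alone.

Of the compounds shown here, three on a shared core have been measured in a functional assay on MCF7 cells (Homo sapiens) for inhibition; on this read-out lower numbers stand for stronger inhibition and higher numbers for weaker inhibition. Compound 1 `CCCCCCCC[C@@]1(C)SC(=O)C=C1OC` gives > 50 ug/mL, which is a limit and not a number. Compound 2 `CCCCCCCC[C@@]1(C)SC(=O)C=C1OCC(=O)OCC` gives 10.8 ug/mL. Going by the values given here, the one measured step, an at least 4.6-fold lower number from compound 1 to compound 2 (0.66 log units; beyond the scatter), comes with ethoxycarbonyl in place of hydrogen on a saturated chain carbon bound to an oxygen on an unsaturated carbon. Compound 3 `C=CCOC1=CC(=O)S[C@]1(C)CCCCCC` gives > 50 ug/mL, also a limit, so it stands at the limit of > 50 ug/mL in this assay, at which 2 of the 3 values shown sit.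

Compound 4 `C=CCOC1=CC(=O)S[C@]1(C)CCCCCCCC` differs from compound 3 by ethyl in place of hydrogen on a saturated chain carbon, six bonds along the chain from a saturated ring carbon. Among the compounds with values here, no measured step changes this chain, and the step to compound 2 lies at another place, so it is only a loose guide. Compound 4 shares its chain with compound 1, whose > 50 ug/mL is again a limit. Only a small shift toward lower numbers in this assay is therefore expected, perhaps none beyond the scatter. The expected change is an at least 1.1-fold lower number from compound 3 to compound 4 (0.04 log units; that floor lies within the scatter). For compound 4 the estimated value is 45 ug/mL, with an expected range from 20 ug/mL to 100 ug/mL.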

Compound 4, half-maximal inhibitory concentration: > 50 ug/mL
Compound 4 ended at the assay's limit (the forecaster's own chance of this, stated with the estimate: 65%); at least 1.1-fold (0.04 log units) between middle value and limit.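

In this assay compound 4 gives > 50 ug/mL, a limit of the assay. The steps from compound 3 and from compound 1 to compound 4 have limits at both ends and cannot be read, so the ethyl added to the chain shows no readable effect. Vinyl in place of ethoxycarbonyl on a saturated chain carbon bound to an oxygen on an unsaturated carbon does give a reading, an at least 4.6-fold higher number from compound 2 to compound 4 (0.66 log units; beyond the scatter), and only one of the four values stands clear of the limit: the limit of > 50 ug/mL in this assay, at which 3 of the 4 values shown sit.

The compounds shown leave open whether the ethoxycarbonyl group would give a readable value on the shorter chain of compound 3. They also leave open whether a carboxylic acid or an amide at that place would do the same.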